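Side chain change on compound 3

A few compounds are considered here, and "the series" means these few. Any claim that something is new, unique, unknown or untested is made for them only; others in the source may bear on it.

Values in a functional assay on HT-29 cells (Homo sapiens) for inhibition, read by MTT assay, with a stated time of 48 h (on this read-out lower numbers stand for stronger inhibition and higher numbers for weaker inhibition), are:
- compound 1 `COc1ccc(CSc2nnc(-c3cc(OC)c(OC)c(OC)c3)n2-c2ccc(OC)cc2)cc1` gives > 60000 nM
- compound 2 `COc1ccc(-n2c(SCC(=O)c3ccc(F)cc3)nnc2-c2cc(OC)c(OC)c(OC)c2)cc1` gives 42500 nM
- compound 3 `COc1ccc(CSc2nnc(-c3cc(OC)c(OC)c(OC)c3)n2-c2ccc(N(C)C)cc2)cc1` gives > 60000 nM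

Compound 3 gives only a limit (> 60000 nM). Compound 1 is also a limit (> 60000 nM). The dimethylamino change shows a step that the two limits leave unreadable from compound 1 to compound 3 and so offers no guide.

Compound 4 `COc1cc(-c2nnc(SCC(=O)C3CC3)n2-c2ccc(N(C)C)cc2)cc(OC)c1OC` carries cyclopropylcarbonyl in place of 4-methoxyphenyl on a saturated chain carbon bound to a sulfur. The closest measured change puts (4-fluorophenyl)carbonyl at that place and shows an at least 1.4-fold lower number from compound 1 to compound 2 (0.14 log units; that floor lies within the scatter), with compound 2 at 42500 nM. Among the compounds with values here, that floor lies within the scatter, and no measured compound carries cyclopropylcarbonyl, so compound 2 is only a loose guide. The expected change is an at least 1.3-fold lower number from compound 3 to compound 4 (0.12 log units; that floor lies within the scatter), small and towards a lower number, and a further limit reading is quite possible. For compound 4 the estimate is 45000 nM, with an expected range of 15000 nM to 90000 nM.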

Compound 4, half-maximal inhibitory concentration: > 60000 nM
Compound 4 ended at the assay's limit; the forecaster's own chance of this, stated with the estimate: 55%; middle value at least 1.3-fold (0.12 log units) from the limit.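

In this assay compound 3 gives a limit, > 60000 nM. Compound 4 also gives a limit, > 60000 nM, so no step can be read between the two. The compounds shown leave open how far cyclopropylcarbonyl in that place shifts the value, because both compounds rest at the same reading: the limit of > 60000 nM in this assay, at which 3 of the 4 values shown sit.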